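Series notes: nitro removal on the sulfonyl ring

This account rests on a few compounds, and the source may have more. Where it says the series, first, only, none or still open, it means among the compounds named here.

Compound 1 `CC(=O)c1ccc(NC(=O)C(CC(C)C)N(C(=O)c2ccccc2)S(=O)(=O)c2ccc([N+](=O)[O-])cc2)cc1`, compound 2 `CCC(C)C(C(=O)Nc1ccc(C(C)=O)cc1)N(C(=O)c1ccccc1)S(=O)(=O)c1ccc([N+](=O)[O-])cc1` and compound 3 `CC(=O)c1ccc(NC(=O)C(C(C)C)N(C(=O)c2ccccc2)S(=O)(=O)c2ccc([N+](=O)[O-])cc2)cc1` share one core and differ only in the side chain on the saturated chain carbon bound to an amide-type nitrogen and a carbonyl carbon. In a functional assay, read by spectrophotometry, with a stated time of 20 min (a lower number here means a stronger inhibitor, a higher number a weaker inhibitor), compound 1 gives 8400000 nM, compound 2 gives 50000000 nM and compound 3 gives 6800000 nM. Compound 2 stands highest of the three numbers: a 6.0-fold higher number from compound 1 to compound 2 (0.77 log units; beyond the scatter), and a 7.4-fold lower number from compound 2 to compound 3 (0.87 log units; beyond the scatter), whereas a 1.2-fold lower number from compound 1 to compound 3 (0.09 log units; within the scatter).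

Compound 4 `CCC(C)C(C(=O)Nc1ccc(C(C)=O)cc1)N(C(=O)c1ccccc1)S(=O)(=O)c1ccccc1` keeps the sec-butyl side chain of compound 2 and differs from it in one place: hydrogen in place of nitro on an aromatic carbon, read one bond further out as (4-nitrophenyl)sulfonyl to phenylsulfonyl. None of the three measured steps touches this ring; all three alter the side chain only. Among the compounds with values here, no measured step therefore bears on the change, and the series gives no ground to expect a shift in this assay beyond the scatter in either direction, so the number of compound 2 is carried over with a wide range. Compound 4 is expected to give 50000000 nM, between 12000000 nM and 200000000 nM. This expectation amounts to no change at the digits printed from compound 2 to compound 4 (within the scatter).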

Compound 4, half-maximal inhibitory concentration: 8600000 nM
For compound 4 the middle estimate is 5.8-fold (0.76 log units) above the measured one, and the stated range ends above it.
By their numbers in this assay, from the lowest: compounds 3, 1 and 4 (each within the scatter of the next); then compound 2.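

In this assay, the sulfonyl ring proves to be a second place where the number moves: hydrogen in place of nitro, on an aromatic carbon para to a large group, gives a 5.8-fold lower number from compound 2 to compound 4 (0.76 log units; beyond the scatter). The nitro group is therefore not needed for inhibition here, and with the sec-butyl side chain the phenylsulfonyl compound is the stronger inhibitor of this pair. Nothing shown accounts for the shift, as no supporting measurement bears on it.

From the compounds shown here alone, this reading rests on a single pair, so it remains open whether the same change holds with the isobutyl side chain of compound 1 or the isopropyl side chain of compound 3. Also open, going by these compounds, is how an amine, a methoxy group or a chlorine atom would read at this place on the ring.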